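Indane for methylindole: exposure expectation for compound 3

The source may hold more compounds than are shown below. What is called first, only, known or untested is meant among the compounds shown, and "the series" means these compounds.

Measured so far in an ADME assay on the whole organism (Rattus norvegicus, strain Sprague-Dawley) for pharmacokinetics, read by LC-MS, with a stated time of 24 h, at a dose of 1 mg/kg by the intravenous route; on this read-out lower numbers stand for lower exposure and higher numbers for higher exposure at the dose given:
compound 1 `CCC(=O)Nc1cc(Nc2ncc(Br)c(Nc3ccc4cc[nH]c4c3)n2)c(OC)cc1N1CCN(C)CC1` gives 314 nM
compound 2 `C=CC(=O)Nc1cc(Nc2ncc(Br)c(Nc3ccc4ccn(C)c4c3)n2)c(OC)cc1N1CCN(C)CC1` gives 397 nM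

Compound 2 has the higher of the two numbers, but its value and that of compound 1 lie within the usual scatter of each other, so neither stands apart. Compound 3 `C=CC(=O)Nc1cc(Nc2ncc(Br)c(Nc3ccc4c(c3)CCC4)n2)c(OC)cc1N1CCN(C)CC1` differs from compound 2 by 2,3-dihydro-1H-inden-5-yl in place of 1-methyl-1H-indol-6-yl on a nitrogen on an aromatic ring. Among the compounds with values here, no step between measured compounds is known here, so the expectation rests on the two values alone: an estimated step of a 1.0-fold lower number from compound 2 to compound 3 (0.02 log units; within the scatter), not beyond the scatter in either direction. Compound 3 is expected to give about 380 nM, likely between 190 nM and 760 nM.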

Compound 3, maximal plasma concentration: 704 nM
Compound 3: the middle estimate sits 1.9-fold (0.27 log units) below what was measured, and the stated range covers the measured number.
By their numbers in this assay, from the lowest: compounds 1, 2 and 3 (each within the scatter of the next, the first and the last beyond it).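

In this assay, putting 2,3-dihydro-1H-inden-5-yl in place of 1-methyl-1H-indol-6-yl on this nitrogen gives a 1.8-fold higher number from compound 2 to compound 3 (0.25 log units; within the scatter). The position therefore accepts a group with no hetero atom in its rings and no hydrogen-bond acceptor, with no step beyond the scatter. Nothing measured here gives a reason for this step.
The compounds shown leave open how the 2,3-dihydro-1H-inden-5-yl ring would read if it carried an amine or a carboxylic acid. They also leave open how a plain phenyl group would read on the same nitrogen.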